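The compounds below may be only part of what the source reports. "The series", "measured", "known", "first", "only" and "open" are said of these compounds alone.

Measured compounds:
compound 1 `CCOC(=O)CN(C)C(=O)c1ccc(C(CC)(CC)c2ccc(OCC(=O)C(C)(C)C)c(C)c2)n1CC`
compound 2 `CCOC(=O)CN(C)C(=O)c1ccc(C(CC)(CC)c2ccc(OCC(O)C(C)(C)C)c(C)c2)n1CC`
compound 3 `C#CC(C)OC(=O)c1ccc(C(CC)(CC)c2ccc(OCC(O)C(C)(C)C)c(C)c2)n1CC`

In an assay on HL-60 cells for agonist activity at vitamin D3 receptor (Homo sapiens), read by microscopy, with a stated time of 96 h (a lower number here means that less compound is needed, a higher number that more compound is needed for the effect), compound 1 gives only a limit of the assay, > 50000 nM. Compound 2 gives 210 nM and compound 3 gives 200 nM. The step of an at least 230-fold lower number from compound 1 to compound 2 (2.37 log units; beyond the scatter) places compound 1 at the limit (the limit of > 50000 nM in this assay, at which 1 of the 3 values shown sits), far from the two numbered values. The step of a 1.1-fold lower number from compound 2 to compound 3 (0.02 log units; within the scatter) shows that exchanging the group on the carbonyl carbon leaves the number essentially unchanged. Compound 4 `CCn1c(C(=O)Nc2ccc(OC(F)(F)F)cc2)ccc1C(CC)(CC)c1ccc(OCC(=O)C(C)(C)C)c(C)c1` is unmeasured; it differs from compound 1 as (4-(trifluoromethoxy)phenyl)amino in place of ((ethoxycarbonyl)methyl)(methyl)amino on a carbonyl carbon, while keeping the (tert-butyl)carbonyl of compound 1. Within the data shown here, with a 1.1-fold lower number from compound 2 to compound 3 (0.02 log units; within the scatter) as the only precedent for a change at the carbonyl carbon, no step beyond the scatter is expected and the limit is expected to persist. Compound 4 is estimated at 60000 nM, range 20000 nM to 200000 nM. The expected step is a step that the limit leaves unreadable from compound 1 to compound 4.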

Compound 4, half-maximal effective concentration: > 50000 nM
Compound 4: a limit, no number; the forecaster's own chance of this, stated with the estimate: 85%; the middle value lies beyond the limit too.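

No step can be read from compound 1 to compound 4, since both stand only as limits of the assay. Still open, going by these compounds, is whether (4-(trifluoromethoxy)phenyl)amino on the carbonyl carbon gives a readable number alongside 1-hydroxy-2,2-dimethylpropyl in place of (tert-butyl)carbonyl.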